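Dichlorinated aryl groups on the core in cytotoxicity

This account rests on a few compounds, and the source may have more. Where it says the series, first, only, none or still open, it means among the compounds named here.

Measured in a functional assay on HT-29 cells (Homo sapiens) for cytotoxicity, read by MTT assay, with a stated time of 48 h; a lower number here means a stronger inhibitor, a higher number a weaker inhibitor:
Compound 1 `CS(=O)(=O)c1ccc(Cc2nnc3n2N=C(c2ccccc2)CS3)cc1`: 25000 nM
Compound 2 `CS(=O)(=O)c1ccc(Cc2nnc3n2N=C(c2cc(Cl)sc2Cl)CS3)cc1`: > 100000 nM (a limit, not a number)

Compound 2 has no number of its own, and its place is the limit of > 100000 nM in this assay, at which 1 of the 2 values shown sits. The next change leads to compound 3 `CS(=O)(=O)c1ccc(Cc2nnc3n2N=C(c2ccc(Cl)cc2Cl)CS3)cc1`: 2,4-dichlorophenyl in place of 2,5-dichlorothiophen-3-yl on a carbon with a double bond to nitrogen. Going by the values given here, only one measured step bears on this place, namely an at least 4.0-fold higher number from compound 1 to compound 2 (0.60 log units; beyond the scatter). That step introduced 2,5-dichlorothiophen-3-yl in place of phenyl, so ring type and chlorine were not varied separately. Compound 3 again has a six-membered aromatic ring of carbon only, as compound 1 does, but it keeps two chlorine atoms. Among the compounds with values here, compound 1, at 25000 nM, is the only measured number. It suggests that a lower number than the limit of compound 2 is expected in this assay. A result at the limit also remains possible, and the size of any step is poorly defined. The estimated step is an at least 2.2-fold lower number from compound 2 to compound 3 (0.34 log units; beyond the scatter). Compound 3 is expected at 45000 nM, with an estimated range of 12000 nM to 100000 nM.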

Compound 3, half-maximal inhibitory concentration: > 100000 nM
Compound 3 was reported as a limit; the forecaster's own chance of this, stated with the estimate: 30%; at least 2.2-fold (0.34 log units) between middle value and limit.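

In this assay, keeping the six-membered aromatic ring of carbon only and placing 2,4-dichlorophenyl in place of phenyl gives an at least 4.0-fold higher number from compound 1 to compound 3 (0.60 log units; beyond the scatter). The earlier step from compound 1 to compound 2 changed ring type and chlorine together, whereas this one leaves the ring type as in compound 1, so the five-membered aromatic ring with sulfur is not needed for a weaker result at this carbon in these three compounds. Compound 2 and compound 3 are both reported as limits, not numbers, and the step between them cannot be read, so the two dichlorinated groups cannot be ranked: the limit of > 100000 nM in this assay, at which 2 of the 3 values shown sit.

The compounds shown leave open whether a single chlorine on the phenyl ring would already move the result away from compound 1, and whether the position of the chlorine atoms matters. They also leave open how a group without chlorine, such as methoxy or an amine on the phenyl ring, would behave at this carbon, and whether any group here gives a lower number than compound 1.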